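Phenyl Replaces an Amino-Nitro Ring on a Fused Core

The source may report more compounds than this note shows. Statements on the series, on what has been measured and on what is new or still open speak of the compounds shown alone.

Compound 2 `Cc1nc2c3ccccc3ccc2c2nc3c(ccc4ccccc43)c(-c3cc([N+](=O)[O-])ccc3N)c12` gives 43.3 ug/mL in a functional assay, read by spectrophotometry, with a stated time of 15 min (on this read-out lower numbers stand for stronger inhibition and higher numbers for weaker inhibition), the lower end of the two numbers measured, though the two lie within the scatter of each other. Compound 1 `Cc1nc2c3ccccc3ccc2c2nc3c(ccc4ccccc43)c(-c3cccc([N+](=O)[O-])c3)c12` gives 54.2 ug/mL in this assay. Within the data shown here, the one measured step, a 1.3-fold lower number from compound 1 to compound 2 (0.10 log units; within the scatter), is too small to read as a change. Compound 3 `Cc1nc2c3ccccc3ccc2c2nc3c(ccc4ccccc43)c(-c3ccccc3)c12` differs from compound 2 in one place: phenyl in place of 2-amino-5-nitrophenyl on an aromatic carbon. The measured step touches only the amino group and not the nitro group, so it bears on the new change only in part, and it showed nothing beyond the scatter. Among the measured compounds shown here, there is no measured step for removing the nitro group. Compound 3 is therefore expected to give about 50 ug/mL in this assay, estimated between 25 ug/mL and 100 ug/mL. The step of a 1.2-fold higher number from compound 2 to compound 3 (0.06 log units; within the scatter) is expected to stay within the scatter, with no direction claimed.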

Compound 3, half-maximal inhibitory concentration: 84.6 ug/mL
Compound 3: middle estimate off by 1.7-fold (0.23 log units), on the low side; the range from low to high includes it.
By their numbers in this assay, from the lowest: compounds 2, 1 and 3 (each within the scatter of the next).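

With compound 3, the nitro group gets a measured step of its own in this assay and, with hydrogen in its place, that step reads a 1.6-fold higher number from compound 1 to compound 3 (0.19 log units; within the scatter) on the ring carried by the shared core. Exchanging the whole 2-amino-5-nitrophenyl for phenyl on the aromatic carbon opposite the ring nitrogen gives a 2.0-fold higher number from compound 2 to compound 3 (0.29 log units; within the scatter) and so also stays within the scatter, which means that across these three compounds neither the amino group, the nitro group nor the two together has moved the number beyond it. Nothing available explains these numbers.

Still open, going by these compounds, is whether an amino group alone on the phenyl ring would read differently from phenyl. Also open, on these data alone, is whether a carboxylic acid, a methoxy group or a longer chain on that ring would give a step beyond the scatter.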